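Trifluoromethoxy for Trifluoromethyl: Cytotoxicity in Two Cores

The compounds below may be only part of what the source reports. "The series", "measured", "known", "first", "only" and "open" are said of these compounds alone.

Compound 1 `O=[N+]([O-])c1cn2c(n1)OC(COc1ccc(-c3ccc(C(F)(F)F)cc3)cc1)C2`: in an ADME assay on MRC5 cells (Homo sapiens) for cytotoxicity, read by fluorescence, with a stated time of 72 h (a lower number here means a stronger inhibitor, a higher number a weaker inhibitor), compound 1 gives > 64000 nM, which is a limit of the assay rather than a number.
Compound 2 `O=[N+]([O-])c1cn2c(n1)OC(COc1ccc(-c3ccc(OC(F)(F)F)cc3)cc1)C2`: in this assay compound 2 gives > 64000 nM, also a limit.
Compound 3 `CC1(COc2ccc(-c3ccc(C(F)(F)F)cc3)nc2)Cn2cc([N+](=O)[O-])nc2O1`: in this assay compound 3 gives > 64000 nM, again a limit.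

The change from compound 1 to compound 2 is trifluoromethoxy in place of trifluoromethyl on an aromatic carbon. Its step is a step that the two limits leave unreadable from compound 1 to compound 2; the size cannot be read because both values sit at the limit of > 64000 nM in this assay, at which 3 of the 3 values shown sit.

Compound 4 `CC1(COc2ccc(-c3ccc(OC(F)(F)F)cc3)nc2)Cn2cc([N+](=O)[O-])nc2O1` carries the same change on the core of compound 3: trifluoromethoxy in place of trifluoromethyl on an aromatic carbon. The difference between the two cores is not broken down here.

The expected step in this assay is a step that the limit leaves unreadable from compound 3 to compound 4, which like the earlier step rests on nothing more than a limit. Compound 4 is therefore expected to sit at about 100000 nM, most likely reported as a limit, with an expected range from 64000 nM to 300000 nM.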

Compound 4, half-maximal inhibitory concentration: > 64000 nM
Compound 4: a limit, no number (the forecaster's own chance of this, stated with the estimate: 85%); the middle value is on the limit's open side.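

The step from compound 3 to compound 4 cannot be read, as with compound 1 and compound 2, because all these values sit at a limit and give no number: the limit of > 64000 nM in this assay, at which 4 of the 4 values shown sit.

The compounds shown leave open whether trifluoromethoxy in place of trifluoromethyl changes the result in this assay at all, and at what concentration any of these four compounds would reach half-maximal inhibition.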